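The compounds below may be only part of what the source reports. "The series", "measured", "known", "first", "only" and "open" are said of these compounds alone.

Compound 2 `CCOC(=O)c1cc(-c2ccc(Oc3ccccc3)cc2)nn1Cc1cccc(NC(=O)CCl)c1` gives 500 nM in a functional assay on Maver1 cells (Homo sapiens) for inhibition, read by luminescence and CellTiter-Glo, with a stated time of 72 h; a higher number here means a weaker inhibitor, a lower number a stronger inhibitor. It stands second highest of the three numbers in hand: compound 1 `O=C(CCl)Nc1cccc(Cn2nc(-c3ccc(Oc4ccccc4)cc3)cc2CO)c1` gives 400 nM, and the step of a 1.3-fold higher number from compound 1 to compound 2 (0.10 log units; within the scatter) lies within the scatter, whereas compound 3 `C/C=C/C(=O)Nc1cccc(Cn2nc(-c3ccc(Oc4ccccc4)cc3)cc2C(=O)O)c1` gives 31600 nM, far higher than compound 2. Compound 4 `CCOC(=O)c1cc(-c2ccc(Oc3ccccc3)cc2)nn1Cc1ccc(NC(=O)CCl)cc1` is a rearrangement of compound 2: 4-(((chloromethyl)carbonyl)amino)phenyl in place of 3-(((chloromethyl)carbonyl)amino)phenyl on a saturated chain carbon bound to an aromatic nitrogen. Within the data shown here, no measured step in this assay concerns where the chloroacetamide-bearing substituent sits on its ring; the single measured step alters a different part of the shared core. Hence no direction can be supported from the data, and a wide range is appropriate. Compound 4 is estimated at 1200 nM in this assay, range 250 nM to 6000 nM, corresponding to an expected step of a 2.4-fold higher number from compound 2 to compound 4 (0.38 log units; beyond the scatter).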

Compound 4, half-maximal inhibitory concentration: 400 nM
Estimate against measurement, compound 4: 3.0-fold (0.48 log units) above; low and high end bracket the measured number.
By their numbers in this assay, from the lowest: compounds 1, 4 and 2 (each within the scatter of the next); then compound 3.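

In this assay, the step of a 1.3-fold lower number from compound 2 to compound 4 (0.10 log units; within the scatter) lies within the scatter, so this first reading of the change shows that 4-(((chloromethyl)carbonyl)amino)phenyl and 3-(((chloromethyl)carbonyl)amino)phenyl are not told apart on this saturated chain carbon bound to an aromatic nitrogen, with ethoxycarbonyl on the shared core. The earlier compounds shown here all carried the 3-substituted arrangement. No measured data bear on why the two numbers agree.

Still open, from the compounds shown here alone, is whether this agreement holds with hydroxymethyl or an amine in place of ethoxycarbonyl. Also open, going by these compounds, is how a longer chain in place of chloromethyl would read on the 4-substituted ring.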